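This account rests on a few compounds, and the source may have more. Where it says the series, first, only, none or still open, it means among the compounds named here.

Working notes on the series. The core is shared by compound 1 `ClCc1ccccc1Cn1cnc2c(Cl)nc(Cl)nc21`, compound 2 `Nc1nc(Cl)c2ncn(Cc3ccc(CCl)cc3)c2n1`, compound 3 `ClCc1ccccc1Cn1cnc2c(Cl)ncnc21` and compound 4 `Nc1nc(Cl)c2ncn(Cc3ccccc3CCl)c2n1`. In a functional assay on SK-MEL-28 cells (Homo sapiens) for cytotoxicity, read by sulforhodamine B assay, with a stated time of 48 h (on this read-out lower numbers stand for higher toxicity in this test and higher numbers for lower toxicity in this test), compound 3 gives 24600 nM, the only single number shown in the set. For compound 1 this assay gives "not determined" (no result reported). For compound 2 this assay reports only a limit, > 100000 nM, as noted in the limit of > 100000 nM in this assay, at which 1 of the 3 values shown sits. The step from compound 3 to compound 4 replaces (amino in place of hydrogen on an aromatic carbon). Within the data shown here, no step between two measured compounds stands beside it. Compound 4 is expected to show weaker toxicity by a 2.8-fold higher number from compound 3 to compound 4 (0.45 log units; beyond the scatter), given that compound 2, which carries the same amino group, gives > 100000 nM. Compound 4 is therefore estimated at 70000 nM, within 25000 nM to 160000 nM.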

Compound 4, concentration lethal to 50% of the cells: 74100 nM
For compound 4 the middle estimate is 1.1-fold (0.02 log units) below the measured one, and the stated range covers the measured number.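

In this assay, among these compounds, amino in place of hydrogen on the aromatic carbon between two ring nitrogen atoms gives the first readable step at this position: a 3.0-fold higher number from compound 3 to compound 4 (0.48 log units; beyond the scatter). The change therefore moves toxicity in this test in the weaker direction, while compound 4 still gives a single number. Compound 2, which carries the same amino group, remains a limit of the assay: the limit of > 100000 nM in this assay, at which 1 of the 4 values shown sits.

Compound 1, with chloro at this position, gives "not determined" (no result reported), so that group cannot be compared here. Going by these compounds, how a methylamino or methoxy group would read at this position remains open.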